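The source may hold more compounds than are shown below. What is called first, only, known or untested is meant among the compounds shown, and "the series" means these compounds.

Series values in a functional assay on HepG2 cells (Homo sapiens) for antiproliferative activity, read by MTT assay; on this read-out higher numbers stand for weaker inhibition and lower numbers for stronger inhibition:
- compound 1 `CC(=O)c1ccc(-n2cc(COc3ccc(/C=C/C(=O)c4cc5c(cc4O)OC(C)(C)CC5)cc3)nn2)cc1`: "not active" (no number reported)
- compound 2 `CC1(C)CCc2c(ccc(C(=O)/C=C/c3ccc(OCc4cn(-c5ccc(Br)cc5)nn4)cc3)c2O)O1`: 136000 nM
- compound 3 `CCCCCn1cc(COc2ccc(/C=C/C(=O)c3cc4c(cc3O)OC(C)(C)CC4)cc2)nn1`: 95800 nM

Going by the values given here, only two of the three compounds carry a number in this assay. Compound 2 at 136000 nM and compound 3 at 95800 nM lie within the usual scatter of each other, so neither can be ranked ahead of the other. Compound 1 is reported as "not active" (no number reported), with no number to set beside them.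

Compound 4 `CC1(C)CCc2c(ccc(C(=O)/C=C/c3ccc(OCc4cn(Cc5ccc([N+](=O)[O-])cc5)nn4)cc3)c2O)O1` has not yet been measured. It puts 4-nitrobenzyl in place of 4-bromophenyl on an aromatic nitrogen of the five-membered aromatic ring with 3 nitrogen (4-nitrobenzyl in place of 4-bromophenyl on an aromatic nitrogen). Among the compounds with values here, no measured pair isolates a change at this place, so the data offer no direct guide to its size. The expectation therefore rests on the two numbers in hand, compound 2 at 136000 nM and compound 3 at 95800 nM, and no step beyond the scatter is expected. The estimated step is a 1.4-fold lower number from compound 2 to compound 4 (0.13 log units; within the scatter), which would stay within the scatter. Compound 4 may also be expected to return no number, as compound 1 did. For compound 4 the estimated value is 100000 nM, with an expected range of 40000 nM to 250000 nM.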

Compound 4, half-maximal inhibitory concentration: 69900 nM
The estimate for compound 4 lay 1.4-fold (0.16 log units) above the measured number, within the range that was stated.
By their numbers in this assay, from the lowest: compounds 4, 3 and 2 (each within the scatter of the next).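

Going by these compounds alone, this is the first step measured at the aromatic nitrogen of the five-membered ring: in this assay, 4-nitrobenzyl in place of 4-bromophenyl gives a 1.9-fold lower number from compound 2 to compound 4 (0.29 log units; within the scatter). The change is a sizeable one on paper, with the entering group larger by the heavy-atom count and bringing 2 hydrogen-bond acceptors where the leaving group has none, yet the number stays within the scatter, so this exchange at this position leaves the read-out effectively unmoved. No measured information is available to account for this result.

The step changes the ring substituent and the phenyl-to-benzyl attachment together, so the contribution of each cannot be separated here, and an unsubstituted benzyl would be the natural reference point for that question. Going by these compounds, whether any group on this nitrogen can move the number beyond the scatter also remains open, for example a benzyl carrying a carboxylic acid or an amine.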